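Carboxy in Place of Hydroxymethyl on a Weak Chain Amide

This account rests on a few compounds, and the source may have more. Where it says the series, first, only, none or still open, it means among the compounds named here.

The shared core appears in compound 1 `C=C(CC)C(=O)c1ccc(OCC(=O)Nc2ccc3c(C)cc(=O)oc3c2)c(Cl)c1Cl`, which in a functional assay on CLL cells (Homo sapiens) for cytotoxicity, read by MTT assay, with a stated time of 48 h (a lower number here means that less compound is needed, a higher number that more compound is needed for the effect), gives 2800 nM. Compound 3 `C=C(CC)C(=O)c1ccc(OCC(=O)NC2CCN(CC(=O)OC)CC2)c(Cl)c1Cl` gives 10600 nM. Compound 2 `C=C(CC)C(=O)c1ccc(OCC(=O)NCCO)c(Cl)c1Cl` reports only a limit in this assay, > 25000 nM, so no number is known for it; it sits at the limit of > 25000 nM in this assay, at which 1 of the 3 values shown sits. Compound 4 `C=C(CC)C(=O)c1ccc(OCC(=O)NCC(=O)O)c(Cl)c1Cl` differs from compound 2 by carboxy in place of hydroxymethyl on a saturated chain carbon bound to an amide-type nitrogen. Both chain amides measured so far, compound 2 and compound 3, stand well weaker than compound 1, and the change to a carboxy gives no reason in these data for a gain. The step is expected to be a step that the limit leaves unreadable from compound 2 to compound 4, that is, none beyond the scatter, with a limit again likely. Compound 4 is therefore estimated at 30000 nM, between 15000 nM and 60000 nM.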

Compound 4, half-maximal effective concentration: > 25000 nM
Compound 4: only a limit was reported; the forecaster's own chance of this, stated with the estimate: 70%; the middle value lies beyond the limit too.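

Compound 4 reports only a limit, > 25000 nM, and compound 2 also stands at a limit, so no step between these two compounds can be read: the limit of > 25000 nM in this assay, at which 2 of the 4 values shown sit.

Whether carboxy in place of hydroxymethyl changes the effect at all remains open in the compounds shown.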